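The compounds below may be only part of what the source reports. "The series", "measured", "known", "first", "only" and "open" are said of these compounds alone.

Measured compounds:
Compound 1: `C=C1C(=O)OC[C@@H]1CCOC(=O)Nc1ccc(C(C)C)cc1`, 1580 nM
Compound 2: `C=C1C(=O)OC[C@H]1CCOC(=O)Nc1cc(C)cc(C)c1`, 480 nM
Compound 3: `C=C1C(=O)OC[C@H]1CCOC(=O)Nc1ccc(Br)cc1`, 350 nM

Three carbamates built on a shared core were tested in a functional assay on RAW264.7 cells (Mus musculus) for inhibition, with a stated time of 30 min; a lower number here means a stronger inhibitor, a higher number a weaker inhibitor. Compound 1 gives 1580 nM, the highest number of the three and beyond the scatter from both of the others, so it stands as the weakest inhibitor in this set. Compound 2 gives 480 nM, and compound 3 gives 350 nM, the lowest number in the group; the values of compound 2 and compound 3 cannot be set apart from each other with confidence.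

Compound 4 is `C=C1C(=O)OC[C@@H]1CCOC(=O)Nc1ccc(Cl)cc1`, not yet measured in this assay. It differs from compound 1 in a single place: chloro in place of isopropyl on an aromatic carbon. Among the measured compounds shown here, no direct single-change step among the measured compounds shows what this exchange does, so the expectation rests on where compound 1 stands and on the numbers of the other two. Since compound 3, which also carries a halogen on the ring, gives 350 nM, a halogen-bearing compound 4 is expected to move toward the lower numbers of the set rather than stay with compound 1. The step from compound 1 to compound 4 is estimated as a 3.2-fold lower number from compound 1 to compound 4 (0.50 log units; beyond the scatter), a drop beyond the scatter. Compound 4 is accordingly expected to give about 500 nM in this assay, within a range of 200 nM to 1200 nM.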

Compound 4, half-maximal inhibitory concentration: 1070 nM
Beside the measured number, compound 4's estimate is 2.1-fold (0.33 log units) below it, and the stated range covers the measured number.
By their numbers in this assay, from the lowest: compounds 3 and 2 (each within the scatter of the next); then compounds 4 and 1 (each within the scatter of the next).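

In this assay, among the compounds shown here, chloro in place of isopropyl on the aromatic carbon gives the first direct reading at this position, which the earlier compounds could not provide: a 1.5-fold lower number from compound 1 to compound 4 (0.17 log units; within the scatter). The step lies within the scatter, so replacing a group of three carbons with a single chlorine atom produces no change that can be told apart here, and compound 1 and compound 4 stand level in this assay. No measurement at hand bears on why the two groups give such similar results.

Going by these compounds, it remains open whether another group at this place, such as a methoxy group, an amine or a carboxylic acid, would shift the number beyond the scatter, as this one pair spans only isopropyl and chloro. Also open, on these data alone, is what the spatial arrangement at the core and the substitution pattern on the ring each contribute, as compound 2 and compound 3 differ from compound 1 and compound 4 in more than one place and offer no single-change comparison with them.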